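This account rests on a few compounds, and the source may have more. Where it says the series, first, only, none or still open, it means among the compounds named here.

Measured in a functional assay on HCT-116 cells (Homo sapiens) for inhibition, read by MTT assay, with a stated time of 72 h; a lower number here means a stronger inhibitor, a higher number a weaker inhibitor:
- compound 1 `COc1cc2c(Oc3ccc(NC(=O)c4nn(-c5ccccc5C)cc(C)c4=O)cc3)ccnc2cc1OCC(=O)NO`: 9260 nM
- compound 2 `COc1cc2c(Oc3ccc(NC(=O)c4nn(-c5ccccc5C)cc(C)c4=O)cc3F)ccnc2cc1OCCCC(=O)NO`: 2040 nM
- compound 3 `COc1cc2c(Oc3ccc(NC(=O)c4nn(-c5ccccc5F)cc(C)c4=O)cc3)ccnc2cc1OCCCC(=O)NO`: 950 nM

Compound 3, at 950 nM, stands lowest of the three, and its gaps to compound 2 and compound 1 lie beyond the scatter. Compound 4 `COc1cc2c(Oc3ccc(NC(=O)c4nn(-c5ccccc5C)cc(C)c4=O)cc3)ccnc2cc1OCCCC(=O)NO` has methyl in place of fluoro on an aromatic carbon, ortho to a large group, turning 2-fluorophenyl into 2-methylphenyl (methyl in place of fluoro on an aromatic carbon). Among the compounds with values here, no measured pair isolates this change. Compound 2, which also carries 2-methylphenyl, gives 2040 nM, so a modest rise in this assay is expected, of a size near the scatter. The expected move is a 1.6-fold higher number from compound 3 to compound 4 (0.20 log units; within the scatter). Compound 4 is estimated at 1500 nM, with an expected range of 600 nM to 3500 nM.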

Compound 4, half-maximal inhibitory concentration: 640 nM
Estimate against measurement, compound 4: 2.3-fold (0.37 log units) above; the range from low to high includes it.
By their numbers in this assay, from the lowest: compounds 4 and 3 (each within the scatter of the next); then compound 2; then compound 1.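

In this assay the change from 2-fluorophenyl to 2-methylphenyl gives a 1.5-fold lower number from compound 3 to compound 4 (0.17 log units; within the scatter) and so stays within the scatter, on this single pair. Dropping the fluoro group gives a 3.2-fold lower number from compound 2 to compound 4 (0.50 log units; beyond the scatter) and is modest, while 2-(hydroxycarbamoyl)ethyl in place of hydroxycarbamoyl gives a 14-fold lower number from compound 1 to compound 4 (1.16 log units; beyond the scatter) as the largest step shown. Nothing measured here speaks to the cause of these steps. The compounds shown leave open how plain phenyl or 2-chlorophenyl would read at this position, and how a longer chain carrying the hydroxycarbamoyl group would compare.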